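The source may report more compounds than this note shows. Statements on the series, on what has been measured and on what is new or still open speak of the compounds shown alone.

Measured so far in a functional assay on K562 cells (Homo sapiens) for cytotoxicity, read by MTT assay, with a stated time of 48 h; a lower number here means a stronger inhibitor, a higher number a weaker inhibitor:
- compound 1 `COc1ccc(-c2c(-c3cc(OC)c(OC)c(OC)c3)noc2N)cc1`: 40 nM
- compound 2 `COc1ccc(-c2c(-c3cc(OC)c(OC)c(OC)c3)noc2N)cc1OC`: 1270 nM

For the measured compounds named here, compound 1 holds the lower of the two numbers, and the only measured step leads away from it: a 32-fold higher number from compound 1 to compound 2 (1.50 log units; beyond the scatter). This large step, beyond the scatter, comes with methoxy in place of hydrogen on an aromatic carbon.

Compound 3 `COc1cc(-c2noc(N)c2-c2ccc(Cl)cc2)cc(OC)c1OC` keeps the core of compound 1 and changes one group: chloro in place of methoxy on an aromatic carbon. This is chloro in place of methoxy on an aromatic carbon, in words 4-methoxyphenyl to 4-chlorophenyl.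

The measured step bears on this change only in part. Going by the values given here, it alters the same phenyl group, but it adds a substituent instead of exchanging one, and no chloro compound has been measured. It shows that one substitution on this group can move the number a long way, not what chloro will do.

In this assay a moderately higher number is therefore expected, smaller than the measured step, although a result within the scatter remains possible. The expected step is a 4.5-fold higher number from compound 1 to compound 3 (0.65 log units; beyond the scatter). For compound 3 the estimated value is 180 nM, with an expected range from 35 nM to 1200 nM.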

Compound 3, half-maximal inhibitory concentration: 640 nM
Beside the measured number, compound 3's estimate is 3.6-fold (0.55 log units) below it, and the stated range covers the measured number.
By their numbers in this assay, from the lowest: compound 1; then compounds 3 and 2 (each within the scatter of the next).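

In this assay, the exchange of 4-methoxyphenyl for 4-chlorophenyl gives a 16-fold higher number from compound 1 to compound 3 (1.20 log units; beyond the scatter), so this place does not tolerate the replacement of methoxy by chloro without a large rise in the number. The earlier step, a 32-fold higher number from compound 1 to compound 2 (1.50 log units; beyond the scatter), came from adding a methoxy to this phenyl group; the new one shows that exchanging the group para to a large group also moves the number beyond the scatter, and compound 1 stays lowest of the three at 40 nM. No measurement is at hand that would explain the size of either step.

On these data alone, whether any other group at this place can keep a number close to that of compound 1 remains open: fluoro, methyl, ethoxy or dimethylamino would show how closely the result depends on methoxy itself. As far as these compounds go, the rest of the core of compound 1 is the same in all three compounds, so it also remains open whether these steps would keep their size with different groups elsewhere on it.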